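The source may report more compounds than this note shows. Statements on the series, on what has been measured and on what is new or still open speak of the compounds shown alone.

In an ADME assay on Vero cells (Chlorocebus sabaeus) for cytotoxicity, read by MTT assay, with a stated time of 72 h (a higher number here means a weaker inhibitor, a lower number a stronger inhibitor), compound 1 `CC1CN(c2nc3c(cc2[N+](=O)[O-])c(=O)c(C(=O)O)cn3C2CC2)CC(C)O1` stands only at a limit, > 160000 nM, and not at a number. Among the compounds with values here, compound 2 `CC1(C)COCN1c1nc2c(cc1[N+](=O)[O-])c(=O)c(C(=O)O)cn2C1CC1`, the only other compound measured, gives 167000 nM. Compound 3 `CC1CN(c2nc3c(cc2[N+](=O)[O-])c(=O)c(C(=O)O)cn3C(C)(C)C)CC(C)O1` keeps the core of compound 1 but carries tert-butyl in place of cyclopropyl on an aromatic nitrogen. Within the data shown here, the one measured step, a step that the limit leaves unreadable from compound 1 to compound 2, changes a group on an aromatic carbon instead, and it has no readable size. Among the measured compounds shown here, no measured step therefore speaks directly to this change, and no direction can be foreseen. The value of compound 2, 167000 nM, serves only as a guide to the level of this series in this assay. The expected change, a number no higher from compound 1 to compound 3 (the limit leaves the size open), is nothing beyond the usual scatter. For compound 3 the estimated value is 160000 nM, with an expected range from 70000 nM to 350000 nM.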

Compound 3, half-maximal inhibitory concentration: 159000 nM
The estimate for compound 3 lay 1.0-fold (0.00 log units) above the measured number, within the range that was stated.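

Within the data shown here, the earlier compounds differ only in a group on an aromatic carbon, so compound 3 gives the first look at the aromatic nitrogen: with tert-butyl there instead of cyclopropyl, the core of compound 1 gives a real number in this assay, and compound 3 stands at 159000 nM. The change replaces a three-membered ring with a group that has no ring, and the result is a number no higher from compound 1 to compound 3 (the limit leaves the size open). The size of this step cannot be read, because compound 1 stands at a limit: the limit of > 160000 nM in this assay, at which 1 of the 3 values shown sits.

From the compounds shown here alone, what ethyl or phenyl on this same nitrogen would give remains open. Also open, going by these compounds, is how the number would respond to an amide in place of the carboxy group.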